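Removing a Bromine From an Amide That Shows No Inhibition

The source may hold more compounds than are shown below. What is called first, only, known or untested is meant among the compounds shown, and "the series" means these compounds.

Compound 1 `COc1c(Br)cccc1C(=O)Nc1ccccc1` was tested in an assay on isolated protein for inhibition of thiosulfate sulfurtransferase (Homo sapiens), with a stated time of 60 min, in the absence of a further agent; a higher number here means a weaker inhibitor, a lower number a stronger inhibitor. In this assay compound 1 gives > 100000 nM, which is a limit of the assay and not a number. Compound 2 `O=C(Nc1ccccc1)c1cccc(Br)c1` gives > 100000 nM in this assay, again only a limit. Compound 3 `COc1ccc(Br)cc1C(=O)Nc1ccc(Sc2nc3ccccc3s2)cc1` also sits at a limit, > 100000 nM. All three values share (the limit of > 100000 nM in this assay, at which 3 of the 3 values shown sit). The step that the two limits leave unreadable from compound 1 to compound 2, hydrogen in place of methoxy on an aromatic carbon, is therefore unreadable. Compound 4 `COc1ccccc1C(=O)Nc1ccccc1` differs from compound 1 by hydrogen in place of bromo on an aromatic carbon. Among the compounds with values here, no measured step bears directly on this change. Within the data shown here, every value so far is a limit. Compound 4 is accordingly expected to remain at the limit, with an estimated step that the limit leaves unreadable from compound 1 to compound 4. The estimate for compound 4 is 150000 nM, with a range from 50000 nM to 500000 nM.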

Compound 4, half-maximal inhibitory concentration: > 100000 nM
Compound 4: only a limit was reported (the forecaster's own chance of this, stated with the estimate: 85%); the middle value lies beyond the limit too.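

No step can be read from compound 1 to compound 4: both values are limits of the assay and not numbers. In this assay the compounds shown leave open whether losing the bromo or methoxy group changes inhibition at all.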